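This account rests on a few compounds, and the source may have more. Where it says the series, first, only, none or still open, it means among the compounds named here.

Measured in a functional assay on DU-145 cells (Homo sapiens) for inhibition, read by trypan blue exclusion, with a stated time of 96 h; a lower number here means a stronger inhibitor of growth, a higher number a weaker inhibitor of growth:
- compound 1 `Cc1ccc(/C=C(/SCc2ccc(Cl)cc2)C(=O)c2ccc([N+](=O)[O-])cc2)s1`: 25000 nM
- compound 2 `CN(C)c1ccc(/C=C(/SCc2ccc(Cl)cc2)C(=O)c2ccc([N+](=O)[O-])cc2)cc1`: > 100000 nM

Compound 2 reads > 100000 nM, which is a limit of this assay and not a number. Its place in the series is the limit of > 100000 nM in this assay, at which 1 of the 2 values shown sits.

The next change leads to compound 3 `Cc1ccsc1/C=C(/SCc1ccc(Cl)cc1)C(=O)c1ccc([N+](=O)[O-])cc1`: 3-methylthiophen-2-yl in place of 4-(dimethylamino)phenyl on a double-bonded chain carbon bound to a double-bonded chain carbon. Here 3-methylthiophen-2-yl stands in place of 4-(dimethylamino)phenyl on a double-bonded chain carbon bound to a double-bonded chain carbon.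

Within the data shown here, one measured step bears on this change: an at least 4.0-fold higher number from compound 1 to compound 2 (0.60 log units; beyond the scatter). It lies beyond the scatter and brought in 4-(dimethylamino)phenyl in place of 5-methylthiophen-2-yl. The change now considered runs the other way, removing 4-(dimethylamino)phenyl and restoring a methylthiophene, although with the methyl group at a different position from compound 1. Compound 1 at 25000 nM is therefore the closest reference, and a move to a lower number in this assay is expected. The size of that move remains loosely defined, as compound 2 has only a limit.

The expected step is an at least 4.0-fold lower number from compound 2 to compound 3 (0.60 log units; beyond the scatter). The estimate for compound 3 is 25000 nM, with an expected range of 8000 nM to 80000 nM.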

Compound 3, concentration for 50% growth inhibition: > 100000 nM
Compound 3 was reported as a limit (the forecaster's own chance of this, stated with the estimate: 15%); middle value at least 4.0-fold (0.60 log units) away from the limit.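

The position of the methyl group on the thiophene matters in this assay: 3-methylthiophen-2-yl in place of 5-methylthiophen-2-yl gives an at least 4.0-fold higher number from compound 1 to compound 3 (0.60 log units; beyond the scatter). A methylthiophene on this double-bonded chain carbon therefore does not by itself keep the level of compound 1, and the earlier pair, which changed the whole group, could not show this. The value of compound 3, > 100000 nM, is a limit of the assay and not a number, so the step from compound 2 to compound 3 cannot be read, and compound 1 remains the only compound here with a measured number: the limit of > 100000 nM in this assay, at which 2 of the 3 values shown sit.

The compounds shown leave open whether compound 2 and compound 3 differ at all in growth inhibition, and how far either lies from the limit. They also leave open whether the methyl group helps in compound 1 or only hinders in compound 3, a question that a plain thiophene without methyl, or an ethyl group in place of the methyl, would bear on.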